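Benzamidomethyl in place of 4-bromophenyl on the shared core

A few compounds are considered here, and "the series" means these few. Any claim that something is new, unique, unknown or untested is made for them only; others in the source may bear on it.

For the measured compounds named here, in a functional assay on MCF7 cells (Homo sapiens) for inhibition, read by MTT assay, with a stated time of 72 h (a lower number here means a stronger inhibitor, a higher number a weaker inhibitor), compound 2 (`Brc1ccc(-c2nnc(SCCCN3CCN(c4nc5ccccc5s4)CC3)o2)cc1`) gives 96300 nM and compound 1 (`O=C(NCc1nnc(SCCCN2CCN(c3nc4ccccc4o3)CC2)o1)c1ccccc1`) gives 52700 nM as the only other number, the two lying within the scatter of each other. Compound 3 (`O=C(NCc1nnc(SCCCN2CCN(c3nc4ccccc4s3)CC2)o1)c1ccccc1`) follows from compound 2 with benzamidomethyl in place of 4-bromophenyl on an aromatic carbon of the five-membered aromatic ring with 2 nitrogen and 1 oxygen (benzamidomethyl in place of 4-bromophenyl on an aromatic carbon). Going by the values given here, no measured pair shows this change alone, so the expectation has little to rest on. The value of compound 1 at 52700 nM gives no reason to expect a large move. The expected change is a 1.6-fold lower number from compound 2 to compound 3 (0.21 log units; within the scatter) in this assay and is estimated to stay within the scatter, leaning slightly toward a lower number. For compound 3 the estimated value is 60000 nM (expected range 25000 nM to 130000 nM).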

Compound 3, half-maximal inhibitory concentration: 39000 nM
For compound 3 the middle estimate is 1.5-fold (0.19 log units) above the measured one, within the range that was stated.
By their numbers in this assay, from the lowest: compounds 3, 1 and 2 (each within the scatter of the next, the first and the last beyond it).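

On the aromatic carbon of the shared core, benzamidomethyl in place of 4-bromophenyl gives a 2.5-fold lower number from compound 2 to compound 3 (0.39 log units; beyond the scatter) in this assay, a modest step and the only one here beyond the scatter, so this position responds to a change of group, if weakly. On the amine nitrogen in a ring, 1,3-benzothiazol-2-yl in place of 1,3-benzoxazol-2-yl gives a 1.4-fold lower number from compound 1 to compound 3 (0.13 log units; within the scatter), so with benzamidomethyl on the core this exchange has no readable effect. Nothing at hand accounts for the step at the aromatic carbon.

Still open, going by these compounds, is whether the step follows the amide or the benzene ring of benzamidomethyl, since both differ from 4-bromophenyl in one exchange. Also open, on these data alone, is how a simple amine, a carboxylic acid or a longer chain on that aromatic carbon would read in this assay.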